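The source may report more compounds than this note shows. Statements on the series, on what has been measured and on what is new or still open speak of the compounds shown alone.

Compound 3 `CCc1cc2ccccc2nc1-c1cn(CCC(F)(F)C(F)(F)C(F)(F)C(F)(F)C(F)(F)C(F)(F)C(F)(F)C(F)(F)F)nn1` gives 55.9 ug/mL in a functional assay on U-937 cells (Homo sapiens) for cytotoxicity, read by MTT assay, with a stated time of 24 h (a lower number here means a stronger inhibitor, a higher number a weaker inhibitor), the highest of the two numbers shown. Compound 1 `CCCCCCCCCCn1cc(-c2nc3ccccc3cc2CCC)nn1` gives 26.6 ug/mL in this assay, a gap that lies beyond the scatter. Compound 2 `CCCCCc1cc2ccccc2nc1-c1cn(CCC(F)(F)C(F)(F)C(F)(F)C(F)(F)C(F)(F)C(F)(F)C(F)(F)C(F)(F)F)nn1` reaches only a limit in this assay, > 100 ug/mL (the limit of > 100 ug/mL in this assay, at which 1 of the 3 values shown sits). Compound 4 `CCCCc1cc2ccccc2nc1-c1cn(CCC(F)(F)C(F)(F)C(F)(F)C(F)(F)C(F)(F)C(F)(F)C(F)(F)C(F)(F)F)nn1` differs from compound 3 by ethyl in place of hydrogen on a saturated chain carbon, two bonds along the chain from an aromatic carbon. Among the measured compounds shown here, the one measured step that bears on this change runs the other way, cutting the chain down: an at least 1.7-fold lower number from compound 2 to compound 3 (0.25 log units; that floor lies within the scatter). Lengthening the chain again should carry the number back toward the limit seen for compound 2, so an upward step is expected, a 1.4-fold higher number from compound 3 to compound 4 (0.16 log units; within the scatter). For compound 4 the estimate in this assay is 80 ug/mL, with a range from 45 ug/mL to 150 ug/mL.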

Compound 4, half-maximal inhibitory concentration: 59.1 ug/mL
For compound 4 the middle estimate is 1.4-fold (0.13 log units) above the measured one, and the stated range covers the measured number.
By their numbers in this assay, from the lowest: compound 1; then compounds 3 and 4 (each within the scatter of the next). At a limit, above all of these: compound 2.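

In this assay, ethyl and butyl at this position give numbers that cannot be told apart: a 1.1-fold higher number from compound 3 to compound 4 (0.02 log units; within the scatter). The further step, an at least 1.6-fold lower number from compound 2 to compound 4 (0.22 log units; that floor lies within the scatter), is only a floor within the scatter, so it establishes no firm difference between these chains. Compound 2 remains a limit, not a number: the limit of > 100 ug/mL in this assay, at which 1 of the 4 values shown sits.

The compounds shown leave open how far compound 2 actually lies from compound 4. They also leave open whether a much longer chain, or an amine or carboxylic acid on this chain, would move the number beyond the scatter.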